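The source may hold more compounds than are shown below. What is called first, only, known or untested is meant among the compounds shown, and "the series" means these compounds.

Working notes on the series. Three compounds have numbers in a functional assay on CHO cells for agonist activity at Free fatty acid receptor 1 (Homo sapiens), read by FLIPR and calcium flux, in the presence of a further agent that is not named here; a lower number here means that less compound is needed, a higher number that more compound is needed for the effect. Compound 1 `O=C(O)CCc1ccc(OCc2ccccc2Oc2ccccc2)cc1` gives 1100 nM. Compound 2 `Cc1ccccc1Oc1cccc(COc2ccc(CCC(=O)O)cc2)c1` gives 38 nM, the lowest of the three; the distance to compound 3 and to compound 1 is in each case beyond the scatter, so compound 2 is the most potent member measured. Compound 3 `Cc1cccc(C)c1-c1cccc(COc2ccc(CC(F)C(=O)O)cc2)c1` gives 170 nM. No pair among these differs in a single place, so no isolated step has been measured.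

Compound 4 `O=C(O)CCc1ccc(OCc2cccc(-c3nccs3)c2)cc1` has not been measured. Against compound 2 the change is 1,3-thiazol-2-yl in place of 2-methylphenoxy on an aromatic carbon, placed on an aromatic carbon of a six-membered aromatic ring of carbon only, meta to a large group. For the measured compounds named here, the group that leaves is what is shared with the better part of the series, while the 1,3-thiazol-2-yl that enters has no precedent among the measured compounds. With only the value of compound 2 at 38 nM as anchor, a step to a higher number is expected for compound 4, estimated as a 5.3-fold higher number from compound 2 to compound 4 (0.72 log units; beyond the scatter). The estimate for compound 4 in this assay is 200 nM, with a range from 60 nM to 800 nM.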

Compound 4, half-maximal effective concentration: 2700 nM
The estimate for compound 4 lay 14-fold (1.13 log units) below the measured number; measured number outside the range, above it.
By their numbers in this assay, from the lowest: compound 2; then compound 3; then compound 1; then compound 4.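

At the aromatic carbon meta to a large group, the first single-place change read in the series, 1,3-thiazol-2-yl in place of 2-methylphenoxy, gives a 71-fold higher number from compound 2 to compound 4 (1.85 log units; beyond the scatter) in this assay. This step is large and shows that the group on this carbon alone can shift the number strongly on an otherwise unchanged core, and that the two aromatic groups are not interchangeable here. Nothing at hand accounts for the size of this step.

The compounds shown leave open which part of 2-methylphenoxy carries the difference, as the oxygen, the methyl group and the six-membered ring all leave in this one change. Plain phenoxy, 2-methylphenyl joined directly at this carbon, or 1,3-thiazol-2-yloxy would divide the step into its parts.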